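The compounds below may be only part of what the source reports. "The series", "measured", "known", "first", "only" and "open" are said of these compounds alone.

Measured so far in a functional assay on MV4-11 cells (Homo sapiens) for inhibition, read by resazurin assay, with a stated time of 72 h; on this read-out higher numbers stand for weaker inhibition of growth and lower numbers for stronger inhibition of growth:
- compound 1 `COc1ccc(Nc2nccc(-c3sc(SC(C)C)nc3C)n2)c(OC)c1`: 5670 nM
- compound 2 `COc1ccc(N(C)c2nccc(-c3cn(C)c4ccccc34)n2)c(OC)c1`: 2000 nM
- compound 3 `COc1ccc(Nc2nccc(-c3cn(C)c4ccccc34)n2)c(OC)c1`: 3410 nM

Compound 1 gives the highest of the three numbers in this assay; compound 3 lies nearest, within the scatter, while the gap to compound 2 is beyond it. For the measured compounds named here, the only step between measured compounds, a 1.7-fold higher number from compound 2 to compound 3 (0.23 log units; within the scatter), concerns a ring nitrogen and not the five-membered ring of compound 1, so nothing measured bears directly on the change at hand.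

Compound 4 `CCCCOc1nc(C)c(-c2ccnc(Nc3ccc(OC)cc3OC)n2)s1` differs from compound 1 by butoxy in place of isopropylsulfanyl on an aromatic carbon. Going by the values given here, with no relevant step in hand, the expectation is a move of no clear direction, a 1.1-fold lower number from compound 1 to compound 4 (0.05 log units; within the scatter), within the usual scatter. Compound 4 is therefore estimated at 5000 nM, with a range from 1500 nM to 16000 nM.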

Compound 4, concentration for 50% growth inhibition: 7860 nM
Estimate against measurement, compound 4: 1.6-fold (0.20 log units) below, within the range that was stated.
By their numbers in this assay, from the lowest: compounds 2, 3, 1 and 4 (each within the scatter of the next, the first and the last beyond it).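

At this position, on the aromatic carbon next to the ring nitrogen and next to the ring sulfur, exchanging isopropylsulfanyl for butoxy gives a 1.4-fold higher number from compound 1 to compound 4 (0.14 log units; within the scatter) in this assay. For the compounds shown here, the linking atom and the chain change together here, so neither can be read alone, and the pair shows only that this exchange leaves the number within the scatter. Nothing available accounts for the result. Isopropoxy would separate the linking atom from the chain. On these data alone, whether an amine or a carboxylic acid here would move the number beyond the scatter remains open.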